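The source may report more compounds than this note shows. Statements on the series, on what has been measured and on what is new or still open speak of the compounds shown alone.

Measured in a functional assay on MDA-MB-231 cells (Homo sapiens) for antiproliferative activity, read by MTT assay, with a stated time of 48 h (a higher number here means a weaker inhibitor, a lower number a stronger inhibitor), so far:
- compound 1 `O=C(/C=C/c1ccccc1)Nc1cc2c(Nc3ccc(Cl)c(Cl)c3)ncnc2s1` gives 4400 nM
- compound 2 `COc1ccc(/C=C/C(=O)Nc2cc3c(Nc4cc(Cl)cc(Cl)c4)ncnc3s2)cc1` gives 1970 nM
- compound 3 `C#Cc1cccc(Nc2ncnc3sc(NC(=O)/C=C/c4ccccc4)cc23)c1` gives 5050 nM

Compound 3 stands level with compound 1, within the scatter of it, at the upper end of these three numbers. Compound 2 lies lower than compound 3, and that gap goes beyond the scatter.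

Compound 4 `O=C(/C=C/c1ccccc1)Nc1cc2c(Nc3cc(Cl)cc(Cl)c3)ncnc2s1` keeps everything in compound 3 except one group, with 3,5-dichlorophenyl in place of 3-ethynylphenyl on a nitrogen on an aromatic ring. Among the measured compounds shown here, only one measured step touches this nitrogen. It exchanges 3,4-dichlorophenyl for 3-ethynylphenyl and stays within the scatter (a 1.1-fold higher number from compound 1 to compound 3 (0.06 log units; within the scatter)). That step suggests the group on this nitrogen has so far moved the number very little, though it rests on a single pair. Compound 2 does carry the incoming 3,5-dichlorophenyl group and gives a lower number (1970 nM), but it also differs from compound 4 elsewhere, so it only tilts the expectation slightly downward. No change beyond the scatter is therefore expected, and the estimated step is small (a 1.3-fold lower number from compound 3 to compound 4 (0.12 log units; within the scatter)). In this assay compound 4 is estimated at 3800 nM with an expected range from 1800 nM to 8000 nM overall.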

Compound 4, half-maximal inhibitory concentration: 11500 nM
Beside the measured number, compound 4's estimate is 3.0-fold (0.48 log units) below it; the whole stated range lies below it.
By their numbers in this assay, from the lowest: compound 2; then compounds 1 and 3 (each within the scatter of the next); then compound 4.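

The group on this nitrogen is not as indifferent as the earlier pair suggested: in this assay, 3,5-dichlorophenyl in place of 3-ethynylphenyl gives a 2.3-fold higher number from compound 3 to compound 4 (0.36 log units; beyond the scatter), and 3,5-dichlorophenyl in place of 3,4-dichlorophenyl gives a 2.6-fold higher number from compound 1 to compound 4 (0.42 log units; beyond the scatter), whereas 3-ethynylphenyl in place of 3,4-dichlorophenyl gave only a 1.1-fold higher number from compound 1 to compound 3 (0.06 log units; within the scatter). The two dichlorophenyl groups have the same atoms, so their arrangement on the ring alone separates compound 1 from compound 4, and the 3,5-dichlorophenyl group is not favourable on its own, as the lower number of compound 2 had hinted. That lower number goes with the methoxy group, since hydrogen in its place on an aromatic carbon gives a 5.8-fold higher number from compound 2 to compound 4 (0.77 log units; beyond the scatter), and nothing available here explains either this step or those on the nitrogen.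

As far as these compounds go, whether methoxy lowers the number in the same way when 3,4-dichlorophenyl or 3-ethynylphenyl sits on the nitrogen stays open, as this step rests on a single pair. Also open, from the compounds shown here alone, is how a dimethylamino group or a carboxylic acid at that aromatic carbon would compare with methoxy and hydrogen.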